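The compounds below may be only part of what the source reports. "The series", "measured", "known", "first", "only" and "open" are said of these compounds alone.

Compound 1 `Cc1cc(-c2ccccc2NCC2=NCCN2)on1` stands in a functional assay for activation of Alpha-1D adrenergic receptor (Homo sapiens) (on this read-out lower numbers stand for an effect already at smaller amounts and higher numbers for an effect only at larger amounts of compound), only at a limit. In this assay compound 1 gives < 100000 nM, which is a limit of the assay rather than a number (the limit of < 100000 nM in this assay, at which 1 of the 2 values shown sits). Compound 2 `Nc1nccc(-c2ccccc2NCC2=NCCN2)n1` gives 28.8 nM in this assay. Compound 3 `CCO/N=C(\C)c1ccccc1NCC1=NCCN1` has not yet been measured; it differs from compound 1 in one place (a group of 6 heavy atoms (4 carbon, 1 nitrogen, 1 oxygen; no ring) in place of a group of 6 heavy atoms (4 carbon, 1 nitrogen, 1 oxygen; one five-membered aromatic ring with 2 hetero atoms), on an aromatic carbon). Going by the values given here, no measured step connects these structures, so neither size nor direction of the change can be read from the data, and a step beyond the scatter in either direction is possible. Compound 3 is expected to give about 1500 nM, with a range from 100 nM to 20000 nM. That expectation corresponds to an estimated step that the limit leaves unreadable from compound 1 to compound 3.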

Compound 3, half-maximal effective concentration: < 5020 nM
Compound 3: only a limit was reported; the forecaster's own chance of this, stated with the estimate: 20%; the middle value is on the limit's open side.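

In this assay compound 3 gives < 5020 nM, which is a limit. Going by these compounds alone, compound 1 gives < 100000 nM, also a limit, so no step between compound 1 and compound 3 can be read. The compounds shown leave open the size and direction of the change on replacing the 3-methyl-1,2-oxazol-5-yl group.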